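Amide variation on the thienyl lactam series

The source may hold more compounds than are shown below. What is called first, only, known or untested is meant among the compounds shown, and "the series" means these compounds.

Compound 2 `CCOC(=O)c1c(Nc2ccc(I)cc2F)sc2c1CC(C)(C)CNC2=O` carries an ethyl ester on the shared core; in a functional assay on HT-29 cells (Homo sapiens) for antiproliferative activity (a higher number here means a weaker inhibitor, a lower number a stronger inhibitor), compound 2 gives "not determined" (no result reported), so it stands without a number among the measured compounds. Compound 1 `CC1(C)CNC(=O)c2sc(Nc3ccc(I)cc3F)c(C(=O)NCCCO)c2C1` gives 6210 nM in this assay, and compound 3 `CC1(C)CNC(=O)c2sc(Nc3ccc(I)cc3Cl)c(C(N)=O)c2C1` gives 596 nM; these two differ from each other in more than one place, so only their two values are shown. Compound 4 `CC1(C)CNC(=O)c2sc(Nc3ccc(I)cc3F)c(C(=O)N[C@@H]3CCCNC3)c2C1` is the unmeasured analogue; it differs from compound 2 by (piperidin-3-yl)amino in place of ethoxy on a carbonyl carbon. Going by the values given here, no measured step covers this change, and compound 2 itself has no value, so no direction can be read from the data. Compound 4 is expected to fall near the two measured amides, estimated at 2000 nM with a range from 400 nM to 10000 nM.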

Compound 4, half-maximal inhibitory concentration: 91 nM
Compound 4: the middle estimate sits 22-fold (1.34 log units) above what was measured; the whole stated range lies above it.
By their numbers in this assay, from the lowest: compound 4; then compound 3; then compound 1.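

Going by these compounds alone, replacing 3-hydroxypropyl with piperidin-3-yl on the amide-type nitrogen gives a 68-fold lower number from compound 1 to compound 4 (1.83 log units; beyond the scatter) in this assay, the first single-place comparison. The group on this nitrogen therefore has a large effect on the read-out, which the two earlier values could not show. Nothing on hand explains the step. The compounds shown leave open whether the lower number follows the ring or its nitrogen: a 3-aminopropyl chain or a cyclohexyl group on the same nitrogen would separate the two. From the compounds shown here alone, the role of the defined stereocentre also remains open.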